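This account rests on a few compounds, and the source may have more. Where it says the series, first, only, none or still open, it means among the compounds named here.

Measured compounds:
compound 1, `COc1ccc(/C=C2/SC(NN3Cc4ccccc4N=C3c3ccccc3)=NC2=O)cc1OC`, 1000 nM
compound 2, `CCc1ccc(NCC(=O)Nn2c(-c3ccccc3)nc3ccccc3c2=O)cc1`, 2420 nM

In a functional assay on MCF7 cells (Homo sapiens) for cytotoxicity, read by MTT assay, with a stated time of 4 h (on this read-out lower numbers stand for stronger inhibition and higher numbers for weaker inhibition), compound 1 gives 1000 nM, while compound 2 gives 2420 nM. Among the measured compounds shown here, compound 2 thus holds the higher of the two numbers; its only neighbour is compound 1, whose lower number lies beyond the usual scatter of this read-out.

Compound 3, `O=C(CNc1ccc(Br)cc1)Nn1c(-c2ccccc2)nc2ccccc2c1=O`, has not yet been measured in this assay. It differs from compound 2 in a single place: bromo in place of ethyl on an aromatic carbon, para to a large group. For the measured compounds named here, no measured pair in this set shows this particular change, so the data give no size or direction for it. The expected step is a 1.1-fold lower number from compound 2 to compound 3 (0.04 log units; within the scatter), none beyond the scatter. On that basis compound 3 is estimated to give 2200 nM in this assay, with a likely range from 800 nM to 6000 nM.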

Compound 3, half-maximal inhibitory concentration: 15100 nM
Compound 3: the middle estimate sits 6.9-fold (0.84 log units) below what was measured, outside the stated range (above it).
By their numbers in this assay, from the lowest: compound 1; then compound 2; then compound 3.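

In this assay, the change from 4-ethylphenyl to 4-bromophenyl brings a 6.2-fold higher number from compound 2 to compound 3 (0.80 log units; beyond the scatter) and shows that the number responds to what this aromatic carbon, para to a large group, carries. Among the compounds shown here, the earlier pair differed in more than one place, so this is the only step here that isolates a single site. No measurement at hand explains why the number rises with this exchange.

With only one step at this position, the compounds shown leave open whether the rise follows from the entry of bromo or from the departure of ethyl. They also leave open how a chloro group, an amine, a carboxylic acid or a longer chain in the same place would read, and whether any of these would fall nearer compound 2 or compound 3.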